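The source may hold more compounds than are shown below. What is called first, only, known or untested is meant among the compounds shown, and "the series" means these compounds.

Compound 2 `Cn1cc(S(=O)(=O)CC(=O)Nc2cccc(Cl)c2Cl)c2ccccc21` is tested in an ADME assay on HEK-293T cells (Homo sapiens) for cytotoxicity, read by CCK-8 assay, with a stated time of 48 h (a higher number here means that more compound is tolerated, a lower number that less compound is tolerated), where compound 2 reaches only the assay's limit of > 100000 nM. Compound 1 `Cn1cc(S(=O)(=O)CC(=O)Nc2cc(Cl)ccc2Cl)c2ccccc21` likewise reaches only the limit of > 100000 nM. Compound 3 `CCOc1ccccc1NC(=O)CSc1c[nH]c2ccc(Cl)cc12` gives a number, 37600 nM. Compound 4 `Cn1cc(S(=O)(=O)CC(=O)Nc2ccc(Cl)cc2Cl)c2ccccc21` is not yet measured. It differs from compound 2 in one place: 2,4-dichlorophenyl in place of 2,3-dichlorophenyl on an amide-type nitrogen. Among the measured compounds shown here, the only measured step with a change on the same nitrogen, a step that the two limits leave unreadable from compound 1 to compound 2, cannot be read because of the limit of > 100000 nM in this assay, at which 2 of the 3 values shown sit, so no size can be drawn from it. With nothing pointing either way, compound 4 is expected to sit at the same limit, giving an estimated 100000 nM with a range from 40000 nM to 250000 nM. The expected step of a number no higher from compound 2 to compound 4 (the limit leaves the size open) is therefore none beyond the scatter.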

Compound 4, half-maximal cytotoxic concentration: > 100000 nM
Compound 4 ended at the assay's limit (the forecaster's own chance of this, stated with the estimate: 75%); the middle value lies on the limit itself.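

The steps among compound 1, compound 2 and compound 4 cannot be read, because all three stop at the same limit: the limit of > 100000 nM in this assay, at which 3 of the 4 values shown sit.

The compounds shown leave open whether 2,3-dichlorophenyl, 2,4-dichlorophenyl and 2,5-dichlorophenyl differ at all in this assay.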